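The source may hold more compounds than are shown below. What is called first, only, known or untested is meant among the compounds shown, and "the series" means these compounds.

Values in a functional assay on A549 cells (Homo sapiens) for cytotoxicity, read by sulforhodamine B assay, with a stated time of 3 days (a higher number here means that more compound is needed for the effect, a lower number that less compound is needed), so far:
- compound 1 `CCOCc1c(C)coc1-c1ccc2c(c1OC)CCCC2(C)C` gives 22.9 uM
- compound 2 `COc1c(-c2occ(C)c2C(=O)O)ccc2c1CCCC2(C)C` gives 53.5 uM
- compound 3 `COc1c(-c2occ(C)c2COC(C)=O)ccc2c1CCCC2(C)C` gives 28.7 uM

Compound 3 (28.7 uM) holds the middle place of the three numbers, but it is not separated from either neighbour. The comparison with compound 1 shows a 1.3-fold higher number from compound 1 to compound 3 (0.10 log units; within the scatter) and the comparison with compound 2 shows a 1.9-fold lower number from compound 2 to compound 3 (0.27 log units; within the scatter). Only a 2.3-fold higher number from compound 1 to compound 2 (0.37 log units; beyond the scatter) lies beyond the scatter, and it is modest.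

The next compound is compound 4 `COCc1c(C)coc1-c1ccc2c(c1OC)CCCC2(C)C`, with methyl in place of acetyl on an oxygen on a saturated carbon, so acetoxymethyl becomes methoxymethyl. The most relevant measurement is the exchange at this same oxygen, a 1.3-fold higher number from compound 1 to compound 3 (0.10 log units; within the scatter), where ethyl and acetyl gave no separable difference. Compound 1 (22.9 uM) also carries an ether at this oxygen and is the closest measured comparison for compound 4. The step involving the carboxy group bears less directly, since compound 4 has no such group. No step beyond the scatter is therefore expected in this assay. The expected change is a 1.1-fold lower number from compound 3 to compound 4 (0.06 log units; within the scatter) and is estimated to be small. The estimated value for compound 4 is 25 uM (expected range 14 uM to 45 uM).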

Compound 4, concentration for half-maximal effect: 19.4 uM
Beside the measured number, compound 4's estimate is 1.3-fold (0.11 log units) above it; low and high end bracket the measured number.
By their numbers in this assay, from the lowest: compounds 4, 1, 3 and 2 (each within the scatter of the next, the first and the last beyond it).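

In this assay, the oxygen on a saturated carbon now carries three different substituents, methyl, ethyl and acetyl, and none separates from the others: a 1.5-fold lower number from compound 3 to compound 4 (0.17 log units; within the scatter) and a 1.2-fold lower number from compound 1 to compound 4 (0.07 log units; within the scatter) both leave the values indistinguishable. Exchanging acetyl, with its double bond outside aromatic rings and its hydrogen-bond acceptor, for the smaller methyl therefore gives no readable change at this place, so this assay tolerates all three substituents there. The methoxymethyl compound also adds a second ether comparison with the carboxy compound, a 2.8-fold lower number from compound 2 to compound 4 (0.44 log units; beyond the scatter) and, like a 2.3-fold higher number from compound 1 to compound 2 (0.37 log units; beyond the scatter) in the opposite direction, this step is beyond the scatter but modest, whereas acetoxymethyl does not separate from carboxy, with a 1.9-fold lower number from compound 2 to compound 3 (0.27 log units; within the scatter) as the step that goes against a clean split.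

Nothing available here bears on the reason for these numbers. Still open, as far as these compounds go, is whether the tolerance at this oxygen extends to a free hydroxyl, a longer chain such as butyl, or an amine-bearing chain, and whether replacing the carboxy group with an amide would keep it apart from the ethers.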